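The compounds below may be only part of what the source reports. "The series", "measured", "known", "first", "only" and "open" are said of these compounds alone.

Measured so far in a functional assay on HepG2 cells (Homo sapiens) for inhibition, read by MTT assay, with a stated time of 48 h; on this read-out higher numbers stand for weaker inhibition and lower numbers for stronger inhibition:
- compound 1 `Fc1ccccc1CSc1nnc(-c2ccncc2)n1-c1ccccc1` gives > 50000 nM, a limit of the assay.
- compound 2 `Clc1cccc(CSc2nnc(-c3ccncc3)n2-c2ccccc2)c1` gives 11200 nM.
- compound 3 `Brc1ccc(CSc2nnc(-c3ccncc3)n2-c2ccccc2)cc1` gives 12900 nM.

Compound 2 holds the lowest of the two numbers; compound 3 sits within the scatter of it a 1.2-fold higher number from compound 2 to compound 3 (0.06 log units; within the scatter). Compound 4 `Fc1cccc(F)c1CSc1nnc(-c2ccncc2)n1-c1ccccc1` differs from compound 2 in one place: 2,6-difluorophenyl in place of 3-chlorophenyl on a saturated chain carbon bound to a sulfur. The step that bears on this is an at least 4.4-fold lower number from compound 1 to compound 2 (0.64 log units; beyond the scatter), since compound 1, like compound 4, carries fluorine on that ring, and an at least 3.8-fold lower number from compound 1 to compound 3 (0.58 log units; beyond the scatter) points the same way. Compound 4 is therefore expected to turn back toward compound 1, a step of a 2.7-fold higher number from compound 2 to compound 4 (0.43 log units; beyond the scatter) in this assay. Compound 4 is estimated at 30000 nM, between 9000 nM and 100000 nM.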

Compound 4, half-maximal inhibitory concentration: > 50000 nM
Compound 4 ended at the assay's limit (the forecaster's own chance of this, stated with the estimate: 40%); middle value at least 1.6-fold (0.22 log units) away from the limit.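

In this assay the 2,6-difluorophenyl group on a saturated chain carbon bound to a sulfur loses the measurable numbers of the chlorine and bromine compounds, with an at least 4.4-fold higher number from compound 2 to compound 4 (0.64 log units; beyond the scatter) and an at least 3.8-fold higher number from compound 3 to compound 4 (0.58 log units; beyond the scatter) as the steps. A second fluorine-bearing ring thus joins compound 1, while among the compounds shown only the 3-chlorophenyl and 4-bromophenyl rings give numbers. The step for the added fluoro from compound 1 to compound 4 cannot be read, as both compounds sit at one limit: the limit of > 50000 nM in this assay, at which 2 of the 4 values shown sit.

As far as these compounds go, whether fluorine itself or its place on the ring sets these two compounds apart stays open. So does how plain phenyl or 2,6-dichlorophenyl would read on that carbon.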